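The source may report more compounds than this note shows. Statements on the series, on what has been measured and on what is new or still open speak of the compounds shown alone.

Of the compounds shown here, three have been measured so far in a functional assay on XF498 cells (Homo sapiens) for cytotoxicity; a lower number here means a stronger inhibitor, a higher number a weaker inhibitor. Compound 1 (`Cc1ccc(-c2cc3ccccc3c(O)n2)cc1`) gives 7080 nM there, and compound 2 (`Cc1ccc2c(O)nc(-c3ccccc3C)cc2c1`) gives 1990 nM in the same read-out. Compound 3 (`CN1CCN(c2nc(-c3ccc(Cl)cc3)cc3c(N(C)C)cccc23)CC1`) stands at 7300 nM in this assay (level with compound 1 within the scatter, and a clearly weaker inhibitor than compound 2). No two of these compounds differ in one place only, so the data hold no measured step that shows what a single change does.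

Compound 4 (`CN1CCN(c2nc(-c3ccccc3)cc3c(N(C)C)cccc23)CC1`) has not yet been measured. It departs from compound 3 in one place: hydrogen in place of chloro on an aromatic carbon, para to a large group, so that 4-chlorophenyl becomes phenyl (hydrogen in place of chloro on an aromatic carbon). Within the data shown here, with no measured step to draw on, the best anchor is compound 3 itself at 7300 nM and no shift beyond the scatter is expected in this assay in either direction. The expected step of a 1.1-fold lower number from compound 3 to compound 4 (0.05 log units; within the scatter) is therefore estimated to be small. The estimated value for compound 4 is 6500 nM (expected range 2500 nM to 16000 nM).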

Compound 4, half-maximal inhibitory concentration: 9550 nM
Estimate against measurement, compound 4: 1.5-fold (0.17 log units) below; the measured number falls inside the stated range.
By their numbers in this assay, from the lowest: compound 2; then compounds 1, 3 and 4 (each within the scatter of the next).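

In this assay, the change from 4-chlorophenyl to phenyl gives the series its first readable step, a 1.3-fold higher number from compound 3 to compound 4 (0.12 log units; within the scatter), and that step lies within the scatter. The chloro group at this position, para to a large group, can therefore be replaced by hydrogen with no measurable change in this pair, so the chlorine atom is not needed to keep the number at this level. Nothing available accounts for this result or ties it to any property of the chloro group.

This single pair says nothing about whether the position would tolerate other replacements equally well, such as fluoro, methoxy, an amine or a carboxylic acid, any of which could give a step beyond the scatter. It also leaves open whether the same change would be as small on a different core or with the dimethylamino and methylpiperazine-bearing parts of compound 4 altered, and compounds 1 and 2 differ from this pair in too many places to settle that.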